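The compounds below may be only part of what the source reports. "The series", "measured", "known", "first", "only" and "open" are said of these compounds alone.

Compound 1, `COc1ccc(-c2cnc3nc(N)nc(N4CCN(C(=O)NCc5ccc(F)cc5)CC4)c3n2)cc1OC`: 37 nM
Compound 2, `CCOc1nc(N)nc2ncc(-c3ccc(Cl)c(Cl)c3)nc12`: > 10000 nM
Compound 3, `CCOc1nc(N)nc2ncc(-c3ccc(C#N)cc3)nc12`: > 10000 nM

Among the compounds with values here, in a functional assay on cells (T-cell, Homo sapiens) for inhibition (on this read-out higher numbers stand for weaker inhibition and lower numbers for stronger inhibition), compound 1 gives 37 nM, the only actual number among the three measured compounds. For compound 2 this assay reports only a limit, > 10000 nM. For compound 3 it likewise reports only a limit, > 10000 nM. Within the data shown here, the measured picture is shaped by the limit of > 10000 nM in this assay, at which 2 of the 3 values shown sit, and no step between measured compounds differing in a single place is available. Compound 4, `COc1ccc(-c2cnc3nc(N)nc(N4CCN(Cc5ccc(C(C)(C)C)cc5)CC4)c3n2)cc1OC`, has not been measured; it differs from compound 1 in one place: 4-(tert-butyl)benzyl in place of (4-fluorobenzyl)carbamoyl on an amine nitrogen in a ring. Among the measured compounds shown here, with no measured step of this kind to lean on, a loss of potency is expected, an 8.1-fold higher number from compound 1 to compound 4 (0.91 log units; beyond the scatter), beyond the scatter but short of the limit. Compound 4 is thus expected at about 300 nM, within 60 nM to 3000 nM.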

Compound 4, half-maximal inhibitory concentration: 4300 nM
Estimate against measurement, compound 4: 14-fold (1.16 log units) below, and the stated range ends below it.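

In this assay, the group on this ring nitrogen strongly affects inhibition: 4-(tert-butyl)benzyl in place of (4-fluorobenzyl)carbamoyl gives a 120-fold higher number from compound 1 to compound 4 (2.07 log units; beyond the scatter). Both groups have 11 heavy atoms and one six-membered aromatic ring of carbon only, so matching these features did not preserve potency, although only the leaving group has a carbonyl and an amide hydrogen. Nothing shown gives a measured reason for this loss.

On these data alone, it remains open whether the loss follows from removing the carbonyl or amide hydrogen, or from adding the tert-butyl. A plain benzyl or an acetyl group on this nitrogen would help separate these possibilities.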